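The source may report more compounds than this note shows. Statements on the series, on what has been measured and on what is new or still open speak of the compounds shown alone.

Measured compounds:
Compound 1, `CCOC(=O)C1=Cc2ccccc2OC1(OCc1cn(CC(=O)Nc2ccccc2Br)nn1)C(F)(F)F`: in a functional assay on DU-145 cells (Homo sapiens) for inhibition, read by MTT assay, with a stated time of 24 h (on this read-out lower numbers stand for stronger inhibition and higher numbers for weaker inhibition), compound 1 gives only a limit, > 150000 nM.
Compound 2, `CCOC(=O)C1=Cc2ccccc2OC1(OCc1cn(-c2ccc(F)c(Cl)c2)nn1)C(F)(F)F`: in this assay compound 2 gives 21500 nM.
Compound 3, `CCOC(=O)C1=Cc2ccccc2OC1(OCc1cn(CC(=O)Nc2ccc(I)cc2Cl)nn1)C(F)(F)F`: in this assay compound 3 gives 24400 nM.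

On the numbers shown, compound 3 and compound 2 lie within the scatter of each other (a 1.1-fold higher number from compound 2 to compound 3 (0.05 log units; within the scatter)), so compound 3 carries the nominally larger figure without being separable from compound 2. Compound 4 is `CCOC(=O)C1=Cc2ccccc2OC1(OCc1cn(CC(=O)Nc2cccc(F)c2)nn1)C(F)(F)F`. The change is 3-fluorophenyl in place of 2-chloro-4-iodophenyl on an amide-type nitrogen. Among the compounds with values here, one measured step touches the same position: an at least 6.1-fold lower number from compound 1 to compound 3 (0.78 log units; beyond the scatter), whose starting point is a limit (the limit of > 150000 nM in this assay, at which 1 of the 3 values shown sits). That step shows that exchanging the aryl group on the amide-type nitrogen can shift the read-out by a large margin, and compound 1, which carries 2-bromophenyl there, yields no number at all. A higher number than that of compound 3 is expected for compound 4, a 3.3-fold higher number from compound 3 to compound 4 (0.52 log units; beyond the scatter), with a fair chance that this assay again reports only a limit. The estimate for compound 4 is 80000 nM, with a range from 20000 nM to 200000 nM.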

Compound 4, half-maximal inhibitory concentration: > 150000 nM
Compound 4: no number, only a limit; the forecaster's own chance of this, stated with the estimate: 45%; at least 1.8-fold (0.27 log units) between middle value and limit.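

Putting 3-fluorophenyl in place of 2-chloro-4-iodophenyl on the amide-type nitrogen gives an at least 6.1-fold higher number from compound 3 to compound 4 (0.78 log units; beyond the scatter), so among the three aryl groups shown on that nitrogen, only 2-chloro-4-iodophenyl yields a number, while 2-bromophenyl and 3-fluorophenyl do not. With ((3-fluorophenyl)carbamoyl)methyl in place of the 3-chloro-4-fluorophenyl of compound 2 on the aromatic nitrogen, the result is an at least 6.9-fold higher number from compound 2 to compound 4 (0.84 log units; beyond the scatter). Compound 4, like compound 1, gives only a limit, and the step between these two cannot be read: the limit of > 150000 nM in this assay, at which 2 of the 4 values shown sit.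

The compounds shown leave open whether the chlorine or the iodine of compound 3 accounts for its number, as both differ from compound 4 together. They also leave open how an amine or a carboxylic acid on the phenyl group of the amide would read in this assay.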